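A few compounds are considered here, and "the series" means these few. Any claim that something is new, unique, unknown or untested is made for them only; others in the source may bear on it.

Three compounds share one core and differ only in the aryl group carried on a nitrogen of that core. Compound 1 `CCc1ccc(Nc2cc(NC(=O)Nc3cc(OC)cc(OC)c3)ncn2)cc1` gives 23.5% in a functional assay on NCI-H520 cells (Homo sapiens) for inhibition, read by MTT assay, with a stated time of 48 h, tested at 10 uM; a higher number here means more inhibition at the concentration tested (going by the name of the read-out), a lower number less inhibition. Compound 2 `COc1cc(NC(=O)Nc2cc(Nc3ccc(C)c(F)c3)ncn2)cc(OC)c1` gives 30.6% in this assay, and compound 3 `COc1cc(NC(=O)Nc2cc(Nc3cc(F)ccc3OC)ncn2)cc(OC)c1` gives 38%. Compound 3 stands beyond the scatter above compound 1, as the step of a number 14.5 percentage points higher from compound 1 to compound 3 (beyond the scatter) shows, while the step of a number 7.4 percentage points higher from compound 2 to compound 3 (within the scatter) leaves compound 2 within the scatter of it, and the step of a number 7.1 percentage points higher from compound 1 to compound 2 (within the scatter) is likewise within the scatter.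

Compound 4 `COc1cc(NC(=O)Nc2cc(Nc3ccc(OC)c(I)c3)ncn2)cc(OC)c1` is not yet measured. It differs from compound 3 in one place: 3-iodo-4-methoxyphenyl in place of 5-fluoro-2-methoxyphenyl on a nitrogen on an aromatic ring

Every measured step here swaps one aryl group for another at this same nitrogen, and the largest of them is only modest. The move from compound 1 to compound 3 shows that such a swap can shift the number beyond the scatter, yet the other two swaps did not. Among the compounds with values here, with no measured compound carrying a 3-iodo-4-methoxyphenyl group, the step of a number 5 percentage points lower from compound 3 to compound 4 (within the scatter) is expected to stay within the scatter, in either direction. Compound 4 is therefore estimated to give 33% in this assay, with a range from 18% to 48%.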

Compound 4, a percentage reported as inhibition, at one concentration (the size of the read-out at that concentration, not a potency): 46.5%
Compound 4: the middle estimate sits 13.5 percentage points below what was measured, within the range that was stated.
By their numbers in this assay, from the lowest: compounds 1, 2, 3 and 4 (each within the scatter of the next, the first and the last beyond it).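

In this assay the step is a number 8.5 percentage points higher from compound 3 to compound 4 (within the scatter), so this nitrogen can carry an aryl group bearing iodine and the result cannot be told apart from that of the fluorinated methoxyphenyl group of compound 3. Within the data shown here, the 3-iodo-4-methoxyphenyl group does clear the scatter against the two aryl groups without a methoxy, with a number 15.9 percentage points higher from compound 2 to compound 4 (beyond the scatter) and a number 23 percentage points higher from compound 1 to compound 4 (beyond the scatter), the latter being the widest step at this position so far, though still modest. The two methoxy-bearing compounds therefore sit at the upper end of the series, but this is no clean split, as compound 2, which has no methoxy, remains within the scatter of compound 3.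

Nothing available here explains these differences. As far as these compounds go, it remains open whether the iodine matters, which a plain 4-methoxyphenyl group or a 3-chloro-4-methoxyphenyl group would test, and how this nitrogen would respond to a group that is not aromatic, such as a cyclohexyl ring, or to an aryl group carrying a morpholine or a carboxylic acid.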